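Removing a methyl from the lowest-scoring sulfonyl aryl group

A few compounds are considered here, and "the series" means these few. Any claim that something is new, unique, unknown or untested is made for them only; others in the source may bear on it.

Measured in an assay on isolated protein for displacement of a labelled ligand from metabotropic glutamate receptor 5 (Homo sapiens), with a stated time of 60 min, tested at 1 uM; a lower number here means less inhibition, a higher number more inhibition at the concentration tested (going by the name of the read-out):
Compound 1 `COc1ccc2ncc(S(=O)(=O)c3ccc(Cl)c(Cl)c3)c(N3CCC(C)CC3)c2c1`: 87%
Compound 2 `COc1ccc2ncc(S(=O)(=O)c3ccc(C)cc3)c(N3CCC(C)CC3)c2c1`: 90%
Compound 3 `COc1ccc2ncc(S(=O)(=O)c3ccc(C)c(F)c3)c(N3CCC(C)CC3)c2c1`: 73%

Compound 3 stands lowest of the three: in this assay compound 3 falls short of compound 1 by a number 14 percentage points lower from compound 1 to compound 3 (beyond the scatter) and short of compound 2 by a number 17 percentage points lower from compound 2 to compound 3 (beyond the scatter), both beyond the scatter, while the first two compounds are within the scatter of each other (a number 3 percentage points higher from compound 1 to compound 2 (within the scatter)).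

Compound 4 `COc1ccc2ncc(S(=O)(=O)c3cccc(F)c3)c(N3CCC(C)CC3)c2c1` differs from compound 3 by hydrogen in place of methyl on an aromatic carbon. Going by the values given here, no measured step removes a methyl, so none bears directly on this change. Among the compounds with values here, the two steps that exist only fix the starting point: compound 3 is the lowest number here, and the one change that was traced on its own, fluoro for hydrogen, cost a number 17 percentage points lower from compound 2 to compound 3 (beyond the scatter). Within the data shown here, with no step of the same kind to lean on, the expected step from compound 3 to compound 4 is a number 8 percentage points lower from compound 3 to compound 4 (within the scatter), with a wide range. Compound 4 is estimated at 65%, between 45% and 85%.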

Compound 4, a percentage reported as inhibition, at one concentration (the size of the read-out at that concentration, not a potency): 68%
Beside the measured number, compound 4's estimate is 3 percentage points below it; the range from low to high includes it.
By their numbers in this assay, from the lowest: compounds 4 and 3 (each within the scatter of the next); then compounds 1 and 2 (each within the scatter of the next).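

In this assay, removing the methyl from the 3-fluoro-4-methylphenyl group gives a number 5 percentage points lower from compound 3 to compound 4 (within the scatter), so compound 3 and compound 4 cannot be told apart, and this methyl, ortho to a fluoro group, makes no readable difference here. The 3-fluorophenyl group of compound 4 also falls clearly short of the other two aryl groups, with a number 22 percentage points lower from compound 2 to compound 4 (beyond the scatter) and a number 19 percentage points lower from compound 1 to compound 4 (beyond the scatter), so the two fluoro compounds sit lowest of the four with or without the methyl. Nothing measured here accounts for these numbers.

On these data alone, whether a plain phenyl group would score with the fluoro compounds or nearer the higher pair remains open. So does the outcome of putting an amine, a carboxylic acid or a longer chain where the methyl stood.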